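Cyano to chloro on the fused core: expected inhibition

A few compounds are considered here, and "the series" means these few. Any claim that something is new, unique, unknown or untested is made for them only; others in the source may bear on it.

Compounds measured so far in a functional assay on the whole organism with Rattus norvegicus as the target, with a stated time of 4 h, at a dose of 40 mg/kg by the intraperitoneal route; a lower number here means less inhibition, a higher number more inhibition at the dose given (going by the name of the read-out):
compound 1, `Cc1nc2c(CSc3ccccc3)cccn2c1C`, gives 29%;
compound 2, `Cc1nc2c(OCc3ccccc3)cccn2c1C#N`, gives 25%;
compound 3, `CSCc1c(C)nc2c(OCc3ccccc3)cccn12`, gives 29%.

All three numbers sit in a narrow band. Compound 2 has the smallest of them, but its distance to compound 1 and to compound 3 is within the scatter, so no order among the three can be read from the data.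

Compound 4, `Cc1nc2c(OCc3ccccc3)cccn2c1Cl`, has not been measured. It differs from compound 2 in one place: chloro in place of cyano on an aromatic carbon. Among the measured compounds shown here, the only measured step that bears on this change is the one at the same carbon of the shared core, where cyano is also replaced: a number 4 percentage points higher from compound 2 to compound 3 (within the scatter). For the measured compounds named here, that step was within the scatter, and no other pair varies this position. Replacement of cyano by chloro has no direct precedent here, so the step is expected to be of a similar size: none beyond the scatter, in either direction, is expected, a number 2 percentage points higher from compound 2 to compound 4 (within the scatter).

On that basis compound 4 is estimated to give 27% in this assay, with a range from 12% to 42%.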

Compound 4, a percentage reported as inhibition, in the whole organism at one dose (the size of the read-out at that dose, not a potency): 93%
The estimate for compound 4 lay 66 percentage points below the measured number; the measured number lies above the stated range.
By their numbers in this assay, from the lowest: compounds 2, 1 and 3 (each within the scatter of the next); then compound 4.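

In this assay, this carbon of the five-membered aromatic ring proves far from indifferent to its substituent, which the earlier step (a number 4 percentage points higher from compound 2 to compound 3 (within the scatter)) gave no sign of. Chloro in place of cyano gives a number 68 percentage points higher from compound 2 to compound 4 (beyond the scatter), and chloro in place of (methylsulfanyl)methyl gives a number 64 percentage points higher from compound 3 to compound 4 (beyond the scatter), so among the three groups seen here, chloro alone separates from the narrow band, while cyano and (methylsulfanyl)methyl stay within the scatter of each other. Nothing at hand bears on what lies behind this step.

Going by these compounds, whether the step belongs to chloro alone or extends to other groups on this carbon stays open; bromo, fluoro, a bare hydrogen, an amine or a longer alkyl chain would begin to settle that. Also open is whether chloro on this carbon gives a step of similar size when the benzyloxy group of compound 4 is replaced by the sulfur-linked side chain of compound 1, and a read-out at one dose and one time gives no potency for any of these compounds.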